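This account rests on a few compounds, and the source may have more. Where it says the series, first, only, none or still open, it means among the compounds named here.

Measured so far:
- compound 1, `CC(=O)N[C@H]1/C(=N/NC(=S)Nc2ccccc2)O[C@H](CO)[C@@H](O)[C@@H]1O`: 30000 nM
- compound 2, `CC(=O)N[C@H]1/C(=N/NC(=O)Nc2cccc3ccccc23)O[C@H](CO)[C@@H](O)[C@@H]1O`: 154 nM
- compound 3, `CC(=O)N[C@H]1/C(=N/NC(=O)Nc2ccc(Cl)cc2)O[C@H](CO)[C@@H](O)[C@@H]1O`: 170 nM

In an assay on isolated protein (Homo sapiens) for inhibition of HEXA/HEXB (Bos taurus), using a Dixon plot (a higher number here means a weaker inhibitor, a lower number a stronger inhibitor), compound 3 gives 170 nM, the second highest of the three numbers. Its nearest neighbour is compound 2 at 154 nM, within the scatter, so the two cannot be ordered. Within the data shown here, compound 1, the thiourea, gives 30000 nM, a far higher number than either, beyond the scatter; no single-point step connects it to compound 3, so only the two values themselves are compared here.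

Compound 4, `CC(=O)N[C@H]1/C(=N/NC(=O)Nc2ccccc2)O[C@H](CO)[C@@H](O)[C@@H]1O`, has not been measured in this assay. It differs from compound 3 in one place: hydrogen in place of chloro on an aromatic carbon, that is, the 4-chlorophenyl becomes phenyl and the (4-chlorophenyl)amino becomes anilino. Among the measured compounds shown here, no step between measured compounds isolates this change. The loss of the chloro is expected to move the number upward by a modest amount, a 2.4-fold higher number from compound 3 to compound 4 (0.37 log units; beyond the scatter), possibly no further than the scatter, since compound 2 shows that a different aryl group on the urea gives 154 nM, close to compound 3. Compound 4 is therefore estimated at 400 nM, with a range from 150 nM to 1500 nM.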

Compound 4, inhibition constant: 205 nM
Compound 4: middle estimate off by 2.0-fold (0.29 log units), on the high side; the range from low to high includes it.
By their numbers in this assay, from the lowest: compounds 2, 3 and 4 (each within the scatter of the next); then compound 1.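

In this assay, hydrogen in place of chloro on an aromatic carbon, para to a large group, gives a 1.2-fold higher number from compound 3 to compound 4 (0.08 log units; within the scatter) and so does not separate the 4-chlorophenyl from the phenyl on the urea; this single step shows no measurable dependence of the number on the chloro at this position. Compound 4 also carries the same phenyl as compound 1, leaving the urea and the thiourea as the one difference between them: compound 1 gives 30000 nM and compound 4 gives 205 nM in this series, so the large gap seen earlier can now be read on a matched pair rather than across different aryl groups. No measured evidence bears on why the chloro makes so little difference here.

On these data alone, only chloro and hydrogen have been compared at this position, so it remains open whether a methoxy group, an amine or a carboxylic acid there would also leave the number within the scatter. Also open, as far as these compounds go, is whether the chloro would behave the same way at any other carbon of the phenyl ring.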